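The compounds below may be only part of what the source reports. "The series", "measured", "known", "first", "only" and "open" are said of these compounds alone.

Compound 1 `CCN(CC)c1cc(NC(=O)NNc2cc(-c3ccc(F)cc3)c3cnn(C)c3n2)cc(Cl)n1`: 37000 nM
Compound 2 `COc1ccc(-c2cc(NNC(=O)Nc3cc(Br)nc(Br)c3)nc3c2cnn3C)cc1`: 54100 nM
Compound 3 `Cc1nn(C)c2nc(NNC(=O)Nc3cc(Cl)nc(Cl)c3)cc(-c3ccccc3)c12`: 22900 nM

These three compounds were measured in a functional assay on SW620/5-FU cells (Homo sapiens) for cytotoxicity, read by MTT assay, with a stated time of 48 h, in the presence of a further agent that is not named here; on this read-out lower numbers stand for an effect already at smaller amounts and higher numbers for an effect only at larger amounts of compound. All of the numbers are large, so each compound needs a high concentration to show an effect. Compound 1 sits among the three values, and its gaps to compound 2 and to compound 3 both lie within the scatter of repeated measurements. On these numbers, compound 1 cannot be separated from either neighbour.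

The next compound to be tested is compound 4 `Cn1ncc2c(-c3ccc(F)cc3)cc(NNC(=O)Nc3cc(Cl)nc(Cl)c3)nc21`. Compared with compound 1, it has chloro in place of diethylamino on an aromatic carbon, next to the ring nitrogen: chloro in place of diethylamino on an aromatic carbon. Going by the values given here, no two measured compounds differ in one place only, so this exchange has no direct precedent in the data. The nearest guide is compound 3, which carries chloro in that same place and gives 22900 nM, although it also differs from compound 4 elsewhere. That value points to little change, perhaps a slight drift toward lower numbers, and no shift beyond the scatter is expected.

The estimate amounts to an expected 1.4-fold lower number from compound 1 to compound 4 (0.15 log units; within the scatter). For compound 4 the estimated value in this assay is 26000 nM, with an expected range from 10000 nM to 60000 nM.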

Compound 4, half-maximal effective concentration: 9150 nM
Beside the measured number, compound 4's estimate is 2.8-fold (0.45 log units) above it; measured number below the stated range.
By their numbers in this assay, from the lowest: compound 4; then compounds 3, 1 and 2 (each within the scatter of the next, the first and the last beyond it).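

In this assay, going by these compounds alone, replacing diethylamino with chloro on an aromatic carbon, next to the ring nitrogen, gives a 4.0-fold lower number from compound 1 to compound 4 (0.61 log units; beyond the scatter) and provides the first comparison here between two compounds that differ in one place only. Compound 1 could not be separated from compounds 2 and 3, whereas this step lies beyond the scatter, showing that the group at this position can change the number and that chloro here goes with an effect at smaller amounts of compound. No measurement shown accounts for the change, so the step stands as an observation without an explanation.

This single pair leaves open whether the number follows the size of the group at this position or the presence of the amine nitrogen, since diethylamino differs from chloro in both respects. Going by these compounds, a smaller amine such as dimethylamino, a morpholine ring or a fluoro in the same place could help separate these possibilities, and it also remains open whether the step would hold with different groups elsewhere on the shared core.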